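Thiocarbonyl substituent swap from compound 2 to compound 3

A few compounds are considered here, and "the series" means these few. Any claim that something is new, unique, unknown or untested is made for them only; others in the source may bear on it.

Values in a functional assay on KYSE-450 cells (Homo sapiens) for inhibition, read by CCK-8 assay, with a stated time of 48 h; on this read-out lower numbers stand for stronger inhibition and higher numbers for weaker inhibition:
- compound 1 `CCN1CCN(C(=S)SCC(=O)N(Cc2ccc(OC)cc2)c2cc(OC)c(OC)c(OC)c2)CC1`: 3070 nM
- compound 2 `COc1ccc(CN(C(=O)CSC(=S)N2CCOCC2)c2cc(OC)c(OC)c(OC)c2)cc1`: 7220 nM

Compound 2, at 7220 nM, holds the higher of the two numbers and is the weaker inhibitor of this pair. Next is compound 3 `COc1ccc(CN(C(=O)CSC(=S)N2CCc3cc(Br)ccc32)c2cc(OC)c(OC)c(OC)c2)cc1`, not yet measured in this assay. The change is 5-bromo-2,3-dihydro-1H-indol-1-yl in place of morpholin-4-yl on a thiocarbonyl carbon. Going by the values given here, one measured step bears on it, at the same place on a thiocarbonyl carbon: a 2.4-fold higher number from compound 1 to compound 2 (0.37 log units; beyond the scatter). That step is modest but beyond the scatter. Among the compounds with values here, no measured compound carries 5-bromo-2,3-dihydro-1H-indol-1-yl, so the direction is uncertain. A step of similar modest size toward a lower number is tentatively expected in this assay. The expected change is a 2.4-fold lower number from compound 2 to compound 3 (0.38 log units; beyond the scatter). The estimate for compound 3 is 3000 nM, with an expected range of 600 nM to 12000 nM.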

Compound 3, half-maximal inhibitory concentration: > 20000 nM
Compound 3 ended at the assay's limit; the forecaster's own chance of this, stated with the estimate: 5%; middle value at least 6.6-fold (0.82 log units) from the limit.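

In this assay compound 3 is held at a limit of the assay and not at a number: the limit of > 20000 nM in this assay, at which 1 of the 3 values shown sits.

At this position on a thiocarbonyl carbon, 5-bromo-2,3-dihydro-1H-indol-1-yl gives an at least 2.7-fold higher number from compound 2 to compound 3 (0.44 log units; beyond the scatter), and against the 4-ethylpiperazin-1-yl group it gives an at least 6.5-fold higher number from compound 1 to compound 3 (0.81 log units; beyond the scatter). The earlier pair showed only a modest step between two saturated rings, whereas these steps put the larger group with its aromatic ring last among the three, so that group offers no gain in inhibition here.

The true size of both steps stays hidden behind the limit. On these data alone, it remains open whether 2,3-dihydro-1H-indol-1-yl without the bromine would behave like compound 3, and whether 4-methylpiperazin-1-yl or piperidin-1-yl would fall nearer compound 1 or compound 2.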